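The source may hold more compounds than are shown below. What is called first, only, known or untested is meant among the compounds shown, and "the series" means these compounds.

Measured in a functional assay on DU-145 cells (Homo sapiens) for inhibition, read by trypan blue exclusion, with a stated time of 96 h; on this read-out higher numbers stand for weaker inhibition of growth and lower numbers for stronger inhibition of growth:
compound 1 `Cc1ccc(CS/C(=C/c2c(O)cc(O)cc2O)C(=O)c2ccc(Cl)cc2)cc1` gives 50000 nM
compound 2 `Cc1ccc(C)c(/C=C(/Sc2ccc(Br)cc2)C(=O)c2ccc(Cl)cc2)c1` gives 10000 nM
compound 3 `O=C(/C(=C\c1c(O)cc(O)cc1O)SCc1ccc(Cl)c(Cl)c1)c1ccc(Cl)cc1` gives 25000 nM

Compound 3 (25000 nM) lies within the scatter of compound 1 and beyond the scatter from compound 2, whose number is lower. Next is compound 4 `O=C(/C(=C\c1c(O)cc(O)cc1O)Sc1ccc(Br)cc1)c1ccc(Cl)cc1`, with 4-bromophenyl in place of 3,4-dichlorobenzyl on a sulfur. For the measured compounds named here, the only measured step (a 2.0-fold lower number from compound 1 to compound 3 (0.30 log units; within the scatter)) keeps the saturated chain carbon on the sulfur, so it does not measure this change. Going by the values given here, compound 2 (10000 nM) also carries 4-bromophenyl on a sulfur, though no measured step isolates that group. On this thin evidence, a modest move to a lower number is expected in this assay. The expected step is (a 2.1-fold lower number from compound 3 to compound 4 (0.32 log units; beyond the scatter)). For compound 4 the estimate is (12000 nM), with an expected range of (3000 nM to 50000 nM).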

Compound 4, concentration for 50% growth inhibition: 50000 nM
Estimate against measurement, compound 4: 4.2-fold (0.62 log units) below, within the range that was stated.
By their numbers in this assay, from the lowest: compound 2; then compounds 3, 1 and 4 (each within the scatter of the next).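

In this assay the sulfur substituent shows little reach while the 2,4,6-trihydroxyphenyl group is held: 4-bromophenyl gives a 2.0-fold higher number from compound 3 to compound 4 (0.30 log units; within the scatter) and no change at the digits printed from compound 1 to compound 4 (within the scatter). For the compounds shown here, with 4-bromophenyl held on the sulfur, 2,4,6-trihydroxyphenyl in place of 2,5-dimethylphenyl gives a 5.0-fold higher number from compound 2 to compound 4 (0.70 log units; beyond the scatter) and is thus the only one of these steps beyond the scatter. No supporting measurement explains either result. Still open, going by these compounds, is whether an amine or a carboxylic acid on the sulfur substituent would move the number beyond the scatter. Also open, on these data alone, is whether the 2,5-dimethylphenyl effect holds with a benzyl group on the sulfur.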